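Adding a Second Methoxy to Compound 3

The source may hold more compounds than are shown below. What is called first, only, known or untested is meant among the compounds shown, and "the series" means these compounds.

In a functional assay on MCF7 cells (Homo sapiens) for antiproliferative activity, read by sulforhodamine B assay, with a stated time of 72 h (on this read-out lower numbers stand for stronger inhibition and higher numbers for weaker inhibition), compound 3 `COc1ccc(C(=O)/C=C/c2csc3ccccc23)c(O)c1` gives 7500 nM, within the scatter of compound 1 `O=C(/C=C/c1csc2ccccc12)c1ccccc1O` at 6600 nM, while compound 2 `COc1ccc(O)c(C(=O)/C=C/c2csc3ccccc23)c1` gives 750 nM. Compound 4 `COc1cc(O)c(C(=O)/C=C/c2csc3ccccc23)cc1OC` differs from compound 3 by methoxy in place of hydrogen on an aromatic carbon, a methoxy in place of hydrogen on an aromatic carbon. Among the measured compounds shown here, two measured steps bear on this. One is an 8.8-fold lower number from compound 1 to compound 2 (0.94 log units; beyond the scatter), whose methoxy also stands para to a hydroxy group, as the new one does. The other is a 1.1-fold higher number from compound 1 to compound 3 (0.06 log units; within the scatter), which lies within the scatter. For the measured compounds named here, no measured compound carries both methoxy groups, so only part of the larger step is expected. The expected change is a 5.0-fold lower number from compound 3 to compound 4 (0.70 log units; beyond the scatter). Compound 4 is estimated at 1500 nM, with an expected range from 350 nM to 6000 nM.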

Compound 4, half-maximal inhibitory concentration: 710 nM
Estimate against measurement, compound 4: 2.1-fold (0.32 log units) above, within the range that was stated.
By their numbers in this assay, from the lowest: compounds 4 and 2 (each within the scatter of the next); then compounds 1 and 3 (each within the scatter of the next).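

In this assay, the methoxy para to a hydroxy group keeps its effect with a second methoxy ortho to it, giving an 11-fold lower number from compound 3 to compound 4 (1.02 log units; beyond the scatter). The step holds on both cores: the same change on two cores in this assay, an 8.8-fold lower number (0.94 log units; beyond the scatter) from compound 1 to compound 2 and an 11-fold lower number (1.02 log units; beyond the scatter) from compound 3 to compound 4, 1.2-fold (0.08 log units) apart, within the scatter of two such steps

The other methoxy again leaves the number within the scatter, with a 1.1-fold lower number from compound 2 to compound 4 (0.02 log units; within the scatter), so the two methoxy groups show no interaction here: the same change on two cores in this assay, a 1.1-fold higher number (0.06 log units; within the scatter) from compound 1 to compound 3 and a 1.1-fold lower number (0.02 log units; within the scatter) from compound 2 to compound 4, 1.2-fold (0.08 log units) apart, within the scatter of two such steps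

Open, as far as these compounds go, is whether the gain belongs to methoxy alone or would also come with an ethoxy or an amine at this position.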